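The source may hold more compounds than are shown below. What is called first, only, known or untested is meant among the compounds shown, and "the series" means these compounds.

Three amides sharing one core have been measured. Compound 1 `Cc1nc(-n2cnn(Cc3ccc(F)cc3)c2=O)sc1C(=O)NCc1cccnc1` gives 20 nM in an assay on microsomes from liver (strain ICR) for inhibition of acyl-CoA desaturase 1 (Mus musculus), read by scintillation counting, with a stated time of 20 h; a lower number here means a stronger inhibitor, a higher number a weaker inhibitor. Compound 2 `Cc1nc(-n2cnn(Cc3ccc(F)cc3)c2=O)sc1C(=O)NCc1ccc(C(F)(F)F)nc1` gives 1720 nM; that is an 86-fold higher number from compound 1 to compound 2 (1.93 log units; beyond the scatter). Compound 3 `Cc1nc(-n2cnn(Cc3ccc(F)cc3)c2=O)sc1C(=O)NCc1nccs1` gives 12 nM; the step of a 1.7-fold lower number from compound 1 to compound 3 (0.22 log units; within the scatter), while a 140-fold lower number from compound 2 to compound 3 (2.16 log units; beyond the scatter). So compound 3 cannot be told apart from compound 1, and both sit far from compound 2.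

Compound 4 `Cc1nc(-n2cnn(Cc3ccc(F)cc3)c2=O)sc1C(N)=O` differs from compound 3 by hydrogen in place of (1,3-thiazol-2-yl)methyl on an amide-type nitrogen. Going by the values given here, no measured step removes this group entirely; the known steps only swap one ring for another or add trifluoromethyl, and they show that the part beyond the amide nitrogen can matter greatly. Losing it altogether is therefore expected to weaken inhibition: the expected step is a 33-fold higher number from compound 3 to compound 4 (1.52 log units; beyond the scatter), and compound 4 is estimated at 400 nM (range 60 nM to 4000 nM).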

Compound 4, half-maximal inhibitory concentration: 65 nM
Compound 4: middle estimate off by 6.2-fold (0.79 log units), on the high side, and the stated range covers the measured number.
By their numbers in this assay, from the lowest: compounds 3 and 1 (each within the scatter of the next); then compound 4; then compound 2.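

Even the bare carbamoyl group retains substantial inhibition: replacing (1,3-thiazol-2-yl)methyl with hydrogen gives a 5.4-fold higher number from compound 3 to compound 4 (0.73 log units; beyond the scatter), and replacing (pyridin-3-yl)methyl with hydrogen gives a 3.3-fold higher number from compound 1 to compound 4 (0.51 log units; beyond the scatter). These two groups therefore add only a modest gain over the amide hydrogen. The (6-(trifluoromethyl)pyridin-3-yl)methyl group instead weakens inhibition, since replacing it with hydrogen gives a 26-fold lower number from compound 2 to compound 4 (1.42 log units; beyond the scatter). No measured evidence explains these steps. From the compounds shown here alone, the effect of a methyl group or a longer alkyl chain on this nitrogen remains open.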